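Swapping trifluoromethyl for dimethylamino on compound 2

This account rests on a few compounds, and the source may have more. Where it says the series, first, only, none or still open, it means among the compounds named here.

Compound 1 `COc1cc(O)c(C(=O)/C=C/c2ccc(N3CCNCC3)cc2)c(OC)c1`: 67500 nM
Compound 2 `COc1cc(OC)c(C(=O)/C=C/c2ccc(C(F)(F)F)cc2)c(O)c1CC=C(C)C`: 73700 nM
Compound 3 `CCc1c(OC)cc(OC)c(C(=O)/C=C/c2cccc(N3CCNCC3)c2)c1O`: > 100000 nM (a limit, not a number)

In an ADME assay on MCF7-DOX cells (Homo sapiens) for cytotoxicity, read by MTT assay, with a stated time of 48 h (a higher number here means a weaker inhibitor, a lower number a stronger inhibitor), compound 2 gives 73700 nM and stands level with compound 1 within the scatter. Compound 3 reads > 100000 nM, which is a limit of the assay. Compound 4 `COc1cc(OC)c(C(=O)/C=C/c2ccc(N(C)C)cc2)c(O)c1CC=C(C)C` is still unmeasured. It carries dimethylamino in place of trifluoromethyl on an aromatic carbon, para to a large group (dimethylamino in place of trifluoromethyl on an aromatic carbon). Going by the values given here, no measured pair shows this change alone. Set against compound 2, compound 1 carries different groups and still gives 67500 nM, so no step beyond the scatter is expected in this assay, with perhaps a slight drift towards a lower number. The expected step is a 1.5-fold lower number from compound 2 to compound 4 (0.17 log units; within the scatter). Compound 4 is estimated at 50000 nM, with an expected range from 20000 nM to 100000 nM.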

Compound 4, half-maximal inhibitory concentration: > 100000 nM
Compound 4: a limit, no number; the forecaster's own chance of this, stated with the estimate: 20%; at least 2.0-fold (0.30 log units) between middle value and limit.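

Going by these compounds alone, compound 2 and compound 4 differ in one place only, so this pair is the first to isolate dimethylamino in place of trifluoromethyl on an aromatic carbon in this assay. The change gives an at least 1.3-fold higher number from compound 2 to compound 4 (0.13 log units; that floor lies within the scatter). Compound 4 reads as a limit of the assay, so only a floor is known and the true size of the step stays unknown: the limit of > 100000 nM in this assay, at which 2 of the 4 values shown sit.

The compounds shown leave open how a carboxylic acid or a nitrile at this place would read. They also leave open whether this change would read the same way on a different core.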